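This account rests on a few compounds, and the source may have more. Where it says the series, first, only, none or still open, it means among the compounds named here.

Within the data shown here, compound 1, `COc1ccc(Nc2nc(-c3cccc(F)c3)nc3ccc(F)cc23)cc1`, is the one compound of this set with a number rather than a limit: in a functional assay on MCF7 cells (Homo sapiens) for cytotoxicity, read by MTT assay, with a stated time of 48 h (a lower number here means a stronger inhibitor, a higher number a weaker inhibitor), compound 1 gives 48400 nM. Compound 2, `Fc1ccc(Nc2nc(-c3cccc(F)c3)nc3ccc(F)cc23)cc1`, reaches only a limit of the assay, > 50000 nM. Compound 3, `Fc1cccc(-c2nc(Nc3cccc(Br)c3)c3cc(F)ccc3n2)c1`, likewise sits at a limit, > 50000 nM. Compound 4, `Oc1cccc(Nc2nc(-c3cccc(F)c3)nc3ccc(F)cc23)c1`, differs from compound 1 by 3-hydroxyphenyl in place of 4-methoxyphenyl on a nitrogen on an aromatic ring. Among the measured compounds shown here, two measured steps touch the aryl group on that same nitrogen, an at least 1.0-fold higher number from compound 1 to compound 2 (0.01 log units; that floor lies within the scatter) and an at least 1.0-fold higher number from compound 1 to compound 3 (0.01 log units; that floor lies within the scatter), and neither can be read beyond its floor because of the limit of > 50000 nM in this assay, at which 2 of the 3 values shown sit. With weak potency throughout and no readable shift, no step beyond the scatter is expected for compound 4, so a 1.1-fold higher number from compound 1 to compound 4 (0.06 log units; within the scatter) is estimated. Compound 4 is therefore expected to give about 55000 nM, in the range 20000 nM to 150000 nM, quite possibly reported as a limit only.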

Compound 4, half-maximal inhibitory concentration: > 50000 nM
Compound 4: no number, only a limit; the forecaster's own chance of this, stated with the estimate: 60%; the middle value is on the limit's open side.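

In this assay compound 4 also stops at a limit, so 3-hydroxyphenyl, which brings in a hydrogen-bond donor on this nitrogen, gives only a floor: an at least 1.0-fold higher number from compound 1 to compound 4 (0.01 log units; that floor lies within the scatter). The steps from compound 2 and from compound 3 to compound 4 cannot be read. A hydroxy-bearing aryl group therefore joins the fluoro and bromo ones at the same limit, and the measurements at this position remain bounded: the limit of > 50000 nM in this assay, at which 3 of the 4 values shown sit.

On these data alone, what an amine or a carboxylic acid on this aryl group would do in this assay stays open, as does whether any group here gives a number clearly lower than that of compound 1.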